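A few compounds are considered here, and "the series" means these few. Any claim that something is new, unique, unknown or untested is made for them only; others in the source may bear on it.

The account begins with an ADME assay on microsomes from liver (Homo sapiens) for metabolic stability, read by LC-MS, with NADPH named in the record, with a stated time of 60 min, tested at 1 uM, in the absence of a further agent (on this read-out higher numbers stand for a more stable compound and lower numbers for a less stable compound), in which three compounds have been measured. Compound 1 `COc1ccc(-c2c(C)oc3c(N4CC[C@@H](NC(C)=O)C4)cc(C)nc23)cc1OC` reaches a limit of the assay, reported as > 95%. Compound 2 `CC(=O)N[C@@H]1CCN(c2cc(C)nn3c(-c4cccc(S(=O)(=O)N(C)C)c4)c(C)nc23)C1` also reaches a limit of the assay, with > 95%. Compound 3 `COc1ccc(-c2c(C)nc3c(N4CC[C@@H](NC(=O)Nc5ccccc5)C4)cc(C)nn23)cc1OC` likewise gives only a limit, > 95%. Thus compound 3 stands where every measured value stands, at the limit of > 95% in this assay, at which 3 of the 3 values shown sit, so no order among the three compounds can be read from these numbers, and no step between measured compounds differing in one place exists in the set.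

Compound 4 `COc1ccc(-c2c(C)nc3c(N4CC[C@@H](NS(=O)(=O)c5ccc(C(C)=O)cc5)C4)cc(C)nn23)cc1OC` is the next compound, not yet measured in this assay. It differs from compound 3 by (4-acetylphenyl)sulfonyl in place of phenylcarbamoyl on an amine nitrogen. Within the data shown here, with all measured values sitting at the limit, no measured step offers a guide for the size of this change. The step expected in this assay is estimated as a number at least 7 percentage points lower from compound 3 to compound 4 (that floor lies within the scatter), which is none beyond the scatter or a small fall. Compound 4 is therefore expected to give about 88%, within a range from 65% to 99%, in this assay.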

Compound 4, percent of the compound remaining: > 95%
Compound 4: a limit, no number; the forecaster's own chance of this, stated with the estimate: 45%; middle value at least 7 percentage points away from the limit.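

In this assay compound 4 gives > 95%, a limit of the assay and not a number. Compound 3 also gives only a limit, so no step between compound 3 and compound 4 can be read: the limit of > 95% in this assay, at which 4 of the 4 values shown sit.

The compounds shown leave open how their stability ranks and which change, if any, would lower the percent of compound remaining.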